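Series notes: a fluoro step from compound 1

A few compounds are considered here, and "the series" means these few. Any claim that something is new, unique, unknown or untested is made for them only; others in the source may bear on it.

For the measured compounds named here, in a functional assay on SW480 cells (Homo sapiens) for antiproliferative activity, with a stated time of 72 h (on this read-out higher numbers stand for weaker inhibition and lower numbers for stronger inhibition), compound 1 `O=C(COc1ccc(CN2CC=C(c3c[nH]c4ccc(F)cc34)CC2)cc1)NO` gives 1110 nM as the highest of the three numbers measured so far, which makes it the weakest inhibitor of the three, with both other compounds lower beyond the scatter. Compound 3 `Cc1[nH]c2ccccc2c1C1=CCC(NCc2ccc(OCC(=O)NO)cc2)CC1` stands nearest at 367 nM and compound 2 `O=C(COc1ccc(CNC2CC=C(c3c[nH]c4ccc(F)cc34)CC2)c(F)c1)NO` stands furthest at 179 nM on the same read-out. The next compound is compound 4 `O=C(COc1ccc(CN2CC=C(c3c[nH]c4ccc(F)cc34)CC2)c(F)c1)NO`, and the change from compound 1 is counted as fluoro in place of hydrogen on an aromatic carbon with fluoro in place of hydrogen on an aromatic carbon, ortho to a large group and meta to a (hydroxycarbamoyl)methoxy group. Going by the values given here, no measured pair in this set shows that single change on its own, so the data give no direct guide to its size. In this assay a small shift towards a lower number is expected, most likely not beyond the scatter. The estimated move is a 1.3-fold lower number from compound 1 to compound 4 (0.12 log units; within the scatter) on this basis. Compound 4 is estimated at 850 nM (expected range 400 nM to 1800 nM).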

Compound 4, half-maximal inhibitory concentration: 3860 nM
The estimate for compound 4 lay 4.5-fold (0.66 log units) below the measured number; the whole stated range lies below it.
By their numbers in this assay, from the lowest: compound 2; then compound 3; then compound 1; then compound 4.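

In this assay, for the compounds shown here, fluoro in place of hydrogen on this aromatic carbon, ortho to a large group and meta to a (hydroxycarbamoyl)methoxy group, gives a 3.5-fold higher number from compound 1 to compound 4 (0.54 log units; beyond the scatter), the first direct reading of any single change in this set. The step runs towards weaker inhibition and lies beyond the scatter, so on the core of compound 1 this position responds to one added fluorine atom. No measurement at hand bears on what lies behind this rise.

A single step leaves open whether a chloro or methyl group on the same carbon would move the number in the same direction or by a similar amount. It also leaves open whether the fluoro step would have the same direction and size on the cores of compound 2 and compound 3.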